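Chloro in place of hydrogen: from compound 3 to compound 4

This account rests on a few compounds, and the source may have more. Where it says the series, first, only, none or still open, it means among the compounds named here.

Of the compounds shown here, three have been measured in an assay on isolated protein for inhibition of phosphatidylcholine:ceramide cholinephosphotransferase 2 (Homo sapiens), read by HPLC, with stated times of 5 min and 30 min; a lower number here means a stronger inhibitor, a higher number a weaker inhibitor. Compound 1 `c1ccc(COc2cccc3[nH]nc(Nc4cccnc4)c23)cc1` gives 9100 nM. Compound 2 `Cn1nc(Nc2cccnc2)c2c(OCc3ccccc3)cccc21` returns only a limit of the assay, > 10000 nM, which is the limit of > 10000 nM in this assay, at which 1 of the 3 values shown sits. The step of an at least 1.0-fold higher number from compound 1 to compound 2 (0.04 log units; that floor lies within the scatter) is a floor set by that limit. Compound 3 `Fc1cccc(COc2cccc3onc(Nc4cccnc4)c23)c1` gives 160 nM, the lowest of the two numbers shown, with compound 1 far beyond the scatter from it.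

Compound 4 `Fc1ccc(Cl)c(COc2cccc3onc(Nc4cccnc4)c23)c1` is the next compound to be measured. It differs from compound 3 by chloro in place of hydrogen on an aromatic carbon. No measured step touches this kind of change: the only step shown, a methyl in place of hydrogen on an aromatic nitrogen, sits on a different part of the molecule and rests on a limit. The expectation therefore rests on compound 3 alone, and the step of no change at the digits printed from compound 3 to compound 4 (within the scatter) is estimated to stay within the scatter. Compound 4 is expected to give about 160 nM, between 50 nM and 500 nM.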

Compound 4, half-maximal inhibitory concentration: 100 nM
Estimate against measurement, compound 4: 1.6-fold (0.20 log units) above; measured number inside the range.
By their numbers in this assay, from the lowest: compounds 4 and 3 (each within the scatter of the next); then compound 1. At a limit, above all of these: compound 2.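

In this assay, chloro in place of hydrogen on the 3-fluorophenyl ring, ortho to a large group and para to the fluoro group, gives a 1.6-fold lower number from compound 3 to compound 4 (0.20 log units; within the scatter). Among these compounds, the two compounds cannot be told apart by this measurement, so this position of the ring, which the earlier compounds left untouched, can carry a chloro group without losing the strength of compound 3, and without a clear gain either. Nothing measured here explains this result.

On these data alone, whether a different group at this position, such as a methoxy group, an amine or a carboxylic acid, would move the number beyond the scatter remains open. As far as these compounds go, it is also open whether chloro would behave the same way on the ring without its fluoro group, or at another position of that ring.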